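Benzylsulfanyl in Place of Amino at the Sugar-Bearing Core

The compounds below may be only part of what the source reports. "The series", "measured", "known", "first", "only" and "open" are said of these compounds alone.

Measured compounds:
compound 1 `OC[C@H]1OC(n2cnc3c(Nc4ccccc4)nccc32)[C@H](O)[C@@H]1O`: 4%
compound 2 `Nc1nccc2c1ncn2[C@H]1C[C@H](O)[C@@H](CO)O1`: 18%

Of the compounds shown here, two have been measured in a functional assay (Homo sapiens) for inhibition of Nucleic Acid, tested at 100 uM; a lower number here means less inhibition, a higher number more inhibition at the concentration tested (going by the name of the read-out). Compound 1 `OC[C@H]1OC(n2cnc3c(Nc4ccccc4)nccc32)[C@H](O)[C@@H]1O` gives 4% in this assay. Compound 2 `Nc1nccc2c1ncn2[C@H]1C[C@H](O)[C@@H](CO)O1` gives 18% in this assay, which places it highest of the two numbers, with compound 1 as its nearest neighbour at a value lower by a gap that exceeds the scatter. Both numbers are small, so neither compound shows much inhibition at the concentration tested.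

Compound 3 `OC[C@H]1O[C@@H](n2cnc3c(SCc4ccccc4)nccc32)C[C@@H]1O` has not yet been measured in this assay. It differs from compound 2 in one place: benzylsulfanyl in place of amino on an aromatic carbon. Among the measured compounds shown here, no step between two measured compounds isolates this particular change, so its effect can only be guessed from the general level of the two measured values. The account expects a step of a number 8 percentage points lower from compound 2 to compound 3 (within the scatter) for this change, that is, a shift toward lower inhibition that may not exceed the scatter. On that basis compound 3 is expected to give about 10% in this assay, within a range from 0% to 28%.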

Compound 3, a percentage reported as inhibition, at one concentration (the size of the read-out at that concentration, not a potency): 18%
The estimate for compound 3 lay 8 percentage points below the measured number; the measured number falls inside the stated range.
By their numbers in this assay, from the lowest: compound 1; then compounds 2 and 3 (each within the scatter of the next).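

In this assay, among the compounds shown here, the exchange of amino for benzylsulfanyl on an aromatic carbon next to the ring nitrogen gives no change at the digits printed from compound 2 to compound 3 (within the scatter), a first reading of this position that the earlier compounds could not supply. At this single concentration, the read-out therefore does not separate amino, with 1 heavy atom and 1 hydrogen-bond donor, from benzylsulfanyl, with 8 heavy atoms, a six-membered aromatic ring of carbon only and 0 hydrogen-bond donors. Nothing available explains why the two compounds read alike.

The compounds shown leave open whether the sulfur and the benzyl part matter separately, a question that a benzylamino group or a methylsulfanyl group on the same carbon would address. Compound 1, which carries a phenylamino group, differs from compound 2 and compound 3 in more than one place, so it cannot settle how an aromatic ring attached through nitrogen compares with one attached through sulfur.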